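From Iodo to Ethoxy: What to Expect for Compound 3

A few compounds are considered here, and "the series" means these few. Any claim that something is new, unique, unknown or untested is made for them only; others in the source may bear on it.

Measured compounds:
compound 1 `COc1cc(C(=O)c2sc(-c3ccc(I)cc3)cc2N)cc(OC)c1OC`: 400 nM
compound 2 `COc1cc(C(=O)c2sc(-c3ccccc3)cc2N)cc(OC)c1OC`: 11 nM

In a functional assay on L1210 cells (Mus musculus) for antiproliferative activity (a higher number here means a weaker inhibitor, a lower number a stronger inhibitor), compound 1 gives 400 nM, the highest of the two numbers shown. Compound 2 gives 11 nM, and the step of a 36-fold lower number from compound 1 to compound 2 (1.56 log units; beyond the scatter) is the only one available. Compound 3 `CCOc1ccc(-c2cc(N)c(C(=O)c3cc(OC)c(OC)c(OC)c3)s2)cc1` differs from compound 1 by ethoxy in place of iodo on an aromatic carbon. The single measured step shows that removing the iodo brings a large move to lower numbers; whether ethoxy in its place behaves like hydrogen is not shown. Compound 3 is therefore expected to lie between the two, a step of a 4.0-fold lower number from compound 1 to compound 3 (0.60 log units; beyond the scatter), with an estimated 100 nM and a range from 20 nM to 600 nM.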

Compound 3, half-maximal inhibitory concentration: 590 nM
Compound 3: middle estimate off by 5.9-fold (0.77 log units), on the low side; low and high end bracket the measured number.
By their numbers in this assay, from the lowest: compound 2; then compounds 1 and 3 (each within the scatter of the next).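

In this assay, ethoxy in place of iodo gives a 1.5-fold higher number from compound 1 to compound 3 (0.17 log units; within the scatter) and so leaves the number where it stood. Ethoxy in place of hydrogen gives a 54-fold higher number from compound 2 to compound 3 (1.73 log units; beyond the scatter) and shows that the large step seen with iodo is not unique to that group, since both para groups shown sit far from compound 2. Nothing available explains why these two different groups give such similar numbers. Going by these compounds, whether fluoro, methyl or an amine at this place would read close to compound 2 or close to compound 1 and compound 3 remains open.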